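This account rests on a few compounds, and the source may have more. Where it says the series, first, only, none or still open, it means among the compounds named here.

Compound 2 `CC(=O)N1CCC(c2nc(NCc3cccnc3)ncc2-c2cc(C)no2)CC1` gives 238000 nM in a physicochemical assay for solubility, with a stated time of 24 h, at pH 3; on this read-out lower numbers stand for lower solubility and higher numbers for higher solubility. Of the two numbers measured it is the one standing first, but only by a gap that lies within the scatter. Compound 1 `CC(=O)N1CCC(c2nc(NCc3ccccn3)ncc2-c2cc(C)no2)CC1` gives 221000 nM in this assay. Among the measured compounds shown here, the one measured step, a 1.1-fold higher number from compound 1 to compound 2 (0.03 log units; within the scatter), moved the read-out by nothing beyond the scatter. Compound 3 `COCCNc1ncc(-c2cc(C)no2)c(C2CCN(C(C)=O)CC2)n1` differs from compound 2 by methoxymethyl in place of pyridin-3-yl on a saturated chain carbon bound to a nitrogen on an aromatic ring. For the measured compounds named here, no measured pair exchanges a ring for an open chain at this place, so the single step between compound 1 and compound 2 bears on the change only in showing that a swap of the group on that chain carbon left the solubility essentially unchanged. A modest shift is expected for compound 3, the estimated step being a 1.6-fold lower number from compound 2 to compound 3 (0.20 log units; within the scatter). The solubility of compound 3 is therefore estimated at 150000 nM, with a range from 50000 nM to 400000 nM.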

Compound 3, solubility: 233000 nM
For compound 3 the middle estimate is 1.6-fold (0.19 log units) below the measured one, and the stated range covers the measured number.
By their numbers in this assay, from the lowest: compounds 1, 3 and 2 (each within the scatter of the next).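

In this assay the first open chain at this place sits with both ring compounds: methoxymethyl in place of pyridin-3-yl on a saturated chain carbon bound to a nitrogen on an aromatic ring gives a 1.0-fold lower number from compound 2 to compound 3 (0.01 log units; within the scatter) and methoxymethyl in place of pyridin-2-yl gives a 1.1-fold higher number from compound 1 to compound 3 (0.02 log units; within the scatter) with neither step leaving the scatter. The earlier pair had only exchanged one pyridinyl group for another, whereas these compounds show that at this place the read-out does not depend on keeping an aromatic ring. Nothing available explains why the three compounds stand so close together.

Whether a carboxylic acid, an amine or a longer chain in place of methoxymethyl would also stay within the scatter of these compounds remains open. The same question stands for a phenyl ring at this place.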